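The source may report more compounds than this note shows. Statements on the series, on what has been measured and on what is new or still open speak of the compounds shown alone.

Working notes on the series.

Compound 2 `CCNC(=O)[C@H]1OC(n2cnc3c(NC4CCCCC4)ncnc32)[C@H](O)[C@@H]1O` gives 1.7 nM in an assay with adenosine receptor A1 (Rattus norvegicus) as the target (on this read-out higher numbers stand for weaker inhibition and lower numbers for stronger inhibition), the lowest number among the three measured compounds. Compound 3 `C=CCNC(=O)[C@H]1OC(n2cnc3c(NC(CC)CC)ncnc32)[C@H](O)[C@@H]1O` gives 17 nM in this assay, and compound 1 `CCC(CC)Nc1ncnc2c1ncn2C1O[C@H](C(=O)NCc2ccccc2)[C@@H](O)[C@H]1O` gives 104 nM. Among the compounds with values here, the only step in one place among the measured compounds, a 6.1-fold lower number from compound 1 to compound 3 (0.79 log units; beyond the scatter), concerns the amide substituent and not the group on the aromatic nitrogen.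

Compound 4 `CCNC(=O)[C@H]1OC(n2cnc3c(Nc4ccc(OC)cc4)ncnc32)[C@H](O)[C@@H]1O` differs from compound 2 by 4-methoxyphenyl in place of cyclohexyl on a nitrogen on an aromatic ring. Within the data shown here, no measured step touches this position: compound 2 and compound 3 differ there, but they also differ at the amide, so their two values show only that compound 2 stands a good deal lower than compound 3 with both changes together. The expectation for compound 4 therefore rests on the structural change alone, without a measured precedent in this set; an aromatic group with an acceptor in place of the saturated ring on the aromatic nitrogen is expected to give a higher number in this assay, by a step of a 35-fold higher number from compound 2 to compound 4 (1.55 log units; beyond the scatter) that goes beyond the scatter, though its size is uncertain. On this basis compound 4 is estimated at 60 nM in this assay, within a range from 12 nM to 300 nM.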

Compound 4, half-maximal inhibitory concentration: 4.6 nM
Compound 4: the middle estimate sits 13-fold (1.12 log units) above what was measured; measured number below the stated range.
By their numbers in this assay, from the lowest: compound 2; then compound 4; then compound 3; then compound 1.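

Within the data shown here, this is the first measured step at the nitrogen on an aromatic ring with the amide unchanged: in this assay, 4-methoxyphenyl in place of cyclohexyl gives a 2.7-fold higher number from compound 2 to compound 4 (0.43 log units; beyond the scatter). The change is beyond the scatter, so the two groups are not equivalent here, but the step is modest, and compound 4 keeps a low number with an aromatic ring at this position, so a saturated ring is not required for a low number in this pair. The data offer no measurement that accounts for the size of this step.

This single pair changes the ring type and adds the methoxy group together, so it cannot assign the step to either; an unsubstituted phenyl or a 4-chlorophenyl on the same nitrogen would begin to separate the two contributions. As far as these compounds go, it also remains open whether a step of this size holds with other amide substituents, such as those of compound 1 and compound 3, since this pair carries only the amide shared by compound 2 and compound 4.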